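Pentyl to 4-Methylphenyl on an Amide Nitrogen

The source may hold more compounds than are shown below. What is called first, only, known or untested is meant among the compounds shown, and "the series" means these compounds.

Compound 1 `C=CC1=C(C(=O)O)C(c2ccc(OC)cc2)OC1` in a functional assay on QGY7701 cells (Homo sapiens) for cytotoxicity, read by MTT assay, with a stated time of 24 h; a higher number here means a weaker inhibitor, a lower number a stronger inhibitor: > 100000 nM.
Compound 2 `C=CC1=C(C(=O)NCCCCC)C(c2ccc(OC)cc2)OC1` in this assay gives > 100000 nM.

For compound 2 the value is a limit of this assay, not a number. For compound 1 the value is likewise a limit. So the step that the two limits leave unreadable from compound 1 to compound 2 has no readable size, as the limit of > 100000 nM in this assay, at which 2 of the 2 values shown sit, makes clear. Compound 3 `C=CC1=C(C(=O)Nc2ccc(C)cc2)C(c2ccc(OC)cc2)OC1` differs from compound 2 by 4-methylphenyl in place of pentyl on an amide-type nitrogen. For the measured compounds named here, no measured step bears on this change, so no direction can be drawn for this assay. Compound 3 is expected near 100000 nM, with a range from 20000 nM to 300000 nM. The expected step is a number no higher from compound 2 to compound 3 (the limit leaves the size open), most likely ending again at a limit.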

Compound 3, half-maximal inhibitory concentration: > 100000 nM
Compound 3: a limit, no number (the forecaster's own chance of this, stated with the estimate: 70%); the middle value lies on the limit itself.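

No step can be read among compound 1, compound 2 and compound 3, since each value is a limit of the assay, not a number: the limit of > 100000 nM in this assay, at which 3 of the 3 values shown sit.
Going by these compounds, whether any change to the shared core gives a measurable value in this assay stays open.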